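Swapping Anilino for Methoxypiperidinyl on the Shared Core

The source may report more compounds than this note shows. Statements on the series, on what has been measured and on what is new or still open speak of the compounds shown alone.

Of the compounds shown here, three have so far been tested in a functional assay on CHO-K1 cells for antagonist activity at transient receptor potential cation channel subfamily V member 1 (Homo sapiens), read by FLIPR; a lower number here means a stronger inhibitor, a higher number a weaker inhibitor. Compound 1 `CC1CCC(Nc2nc(C(F)(F)F)ccc2CNC(=O)C(C)c2ccc(NS(C)(=O)=O)c(F)c2)CC1` gives 1130 nM, and compound 2 `CC(C(=O)NCc1ccc(C(F)(F)F)nc1Nc1ccccc1)c1ccc(NS(C)(=O)=O)c(F)c1` gives 1400 nM. Compound 3 `CC(C(=O)NCc1ccc(C(F)(F)F)nc1NCc1cccnc1)c1ccc(NS(C)(=O)=O)c(F)c1` is reported as "not active" (no number reported), with no number attached. Of the two numbers, compound 2 holds the higher one, but compound 1 is only a 1.2-fold higher number from compound 1 to compound 2 (0.09 log units; within the scatter) away, within the scatter, so the two cannot be told apart.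

Compound 4 `COC1CCN(c2nc(C(F)(F)F)ccc2CNC(=O)C(C)c2ccc(NS(C)(=O)=O)c(F)c2)CC1` has not yet been measured. It differs from compound 2 in one place: 4-methoxypiperidin-1-yl in place of anilino on an aromatic carbon. Among the measured compounds shown here, the only measured step that touches this position is the one with phenyl in place of 4-methylcyclohexyl, a 1.2-fold higher number from compound 1 to compound 2 (0.09 log units; within the scatter), which stayed within the scatter. Compound 3, carrying a different group on that aromatic carbon, gave no number at all, so changes here are not always harmless. Nothing measured shows how a non-aromatic ring with no hydrogen-bond donor behaves there. The expected step is therefore small, a 1.1-fold higher number from compound 2 to compound 4 (0.06 log units; within the scatter), but with a wide range to cover the gap in what is known. Compound 4 is estimated at 1600 nM, between 500 nM and 5000 nM.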

Compound 4, half-maximal inhibitory concentration: 280 nM
Beside the measured number, compound 4's estimate is 5.7-fold (0.76 log units) above it, and the stated range ends above it.
By their numbers in this assay, from the lowest: compound 4; then compounds 1 and 2 (each within the scatter of the next).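

In this assay, the earlier groups on this aromatic carbon gave either two numbers within the scatter of each other or no number at all, so the position had not yet shown that a change there could lower the number. 4-methoxypiperidin-1-yl now does so, with steps beyond the scatter against both numbered neighbours (a 5.0-fold lower number from compound 2 to compound 4 (0.70 log units; beyond the scatter)) and (a 4.0-fold lower number from compound 1 to compound 4 (0.61 log units; beyond the scatter)), which shows that this carbon can respond to the group it carries and that a modest gain is possible there. The anilino group that leaves has 1 hydrogen-bond donor and the group that enters has 0, so at least in compound 4 a donor on this group is not needed for activity, though nothing at hand explains the gain.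

The compounds shown do not separate the part played by the methoxy group from that of the non-aromatic ring itself, and a plain piperidin-1-yl group on the same core would speak to that directly. From the compounds shown here alone, it also remains open whether the oxygen must sit on the ring as a methoxy group, as a hydroxy group on the same ring or a morpholin-4-yl group would begin to tell.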